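The compounds below may be only part of what the source reports. "The series", "measured", "known", "first", "only" and "open" are said of these compounds alone.

Values in a functional assay on A549 cells (Homo sapiens) for antiproliferative activity, read by MTT assay, with a stated time of 72 h; a higher number here means a weaker inhibitor, a lower number a stronger inhibitor:
- compound 1 `CC(C)CNC(=N)NC(=N)Nc1ccc(F)cc1F`: 3600 nM
- compound 2 `CC(C)CNC(=N)NC(=N)Nc1ccc(F)c(F)c1`: 2400 nM
- compound 3 `CC(C)NC(=N)NC(=N)Nc1ccc(F)c(F)c1`: 5200 nM

Compound 3, at 5200 nM, lies within the scatter of compound 1 and is separated beyond the scatter only from compound 2.

Next in the series is compound 4 `CCN(CC)C(=N)NC(=N)Nc1ccc(F)c(F)c1`, with diethylamino in place of isopropylamino on a carbon with a double bond to nitrogen.

Among the measured compounds shown here, one measured step bears on this change: a 2.2-fold higher number from compound 2 to compound 3 (0.34 log units; beyond the scatter). It is modest and involves the same amine nitrogen, exchanging isobutyl for isopropyl. For the measured compounds named here, no measured compound carries diethylamino, so that step offers only a rough guide to size and does not settle the direction. A step of similar modest size is possible, but none beyond the scatter is expected in this assay, with a slight lean towards a higher number.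

The estimated change is a 1.2-fold higher number from compound 3 to compound 4 (0.06 log units; within the scatter).

For compound 4 the expected value is 6000 nM, with an estimated range of 2500 nM to 14000 nM.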

Compound 4, half-maximal inhibitory concentration: 7800 nM
Beside the measured number, compound 4's estimate is 1.3-fold (0.11 log units) below it; the range from low to high includes it.
By their numbers in this assay, from the lowest: compounds 2, 1, 3 and 4 (each within the scatter of the next, the first and the last beyond it).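

Working in this assay, the exchange of isopropylamino for diethylamino on the carbon with a double bond to nitrogen gives a 1.5-fold higher number from compound 3 to compound 4 (0.18 log units; within the scatter) and so does not separate the two compounds, although diethylamino has no hydrogen-bond donor and isopropylamino has one. The exchange of isobutylamino for diethylamino at the same place gives a 3.3-fold higher number from compound 2 to compound 4 (0.51 log units; beyond the scatter) and is the larger of the two steps, so among these three groups only the isobutylamino and diethylamino compounds stand clearly apart. No supporting data are available to explain either step.

Whether a cyclic amine such as piperidine or morpholine, or a longer chain such as hexylamino, would remain in this range at this place is open. Also open, from the compounds shown here alone, is whether diethylamino would give a similar result on the fluorine pattern of compound 1.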